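Removing the Cyano Group: What to Expect for Compound 4

A few compounds are considered here, and "the series" means these few. Any claim that something is new, unique, unknown or untested is made for them only; others in the source may bear on it.

Compound 1 `C/C(=N\NC(=O)COc1cccc2ccccc12)c1cccc([N+](=O)[O-])c1`: 20 ug/mL
Compound 2 `C/C(=N\NC(=O)COc1cccc2ccccc12)c1ccc(C#N)cc1Br`: 20 ug/mL
Compound 3 `O=C(COc1cccc2ccccc12)N/N=C/C=C/c1ccccc1`: 100 ug/mL

Of the compounds shown here, three built on the same shared core have been tested in an ADME assay on HEL cells (Homo sapiens) for cytotoxicity; on this read-out lower numbers stand for higher toxicity in this test and higher numbers for lower toxicity in this test. Compound 1 gives 20 ug/mL, compound 2 gives 20 ug/mL, and compound 3 gives 100 ug/mL. Compound 2 is level with compound 1 at the digits shown, and the two together stand lowest of the three; compound 3 lies at a higher number, a gap beyond the scatter. Going by the values given here, the one step between measured compounds that differ in a single place put 2-bromo-4-cyanophenyl in place of 3-nitrophenyl on a carbon with a double bond to nitrogen, and it gave no change at the digits printed from compound 1 to compound 2 (within the scatter).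

Compound 4 `C/C(=N\NC(=O)COc1cccc2ccccc12)c1ccccc1Br` has not been measured. Its difference from compound 2 is hydrogen in place of cyano on an aromatic carbon. That earlier step exchanged the whole aryl group without a change beyond the scatter, and the present change, on the same aryl group, is smaller. No step beyond the scatter is therefore expected in this assay. Compound 4 is estimated at 20 ug/mL, with a range from 10 ug/mL to 40 ug/mL. The expected step is no change at the digits printed from compound 2 to compound 4 (within the scatter), within the scatter.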

Compound 4, minimum cytotoxic concentration: 20 ug/mL
For compound 4 middle estimate and measured number coincide at the digits printed; the range from low to high includes it.
By their numbers in this assay, from the lowest: compounds 1, 2 and 4 (each within the scatter of the next); then compound 3.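

In this assay the change from cyano to hydrogen gives no change at the digits printed from compound 2 to compound 4 (within the scatter) and so shows that, on this aryl group, the nitrile can go without a shift beyond the scatter. The bromo group need not be joined by a second group on the ring for this level to hold, since putting 2-bromophenyl in place of 3-nitrophenyl gives no change at the digits printed from compound 1 to compound 4 (within the scatter) as well. No measurement at hand offers a reason why these numbers stay level.

Still open, on these data alone, is whether an amine or a carboxylic acid on the same aromatic carbon would leave the number where it stands. Also open, as far as these compounds go, is what happens when the bromo group itself gives way to hydrogen or to a longer chain such as propyl.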